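The compounds below may be only part of what the source reports. "The series", "measured", "known", "first", "only" and "open" are said of these compounds alone.

Measured so far in a functional assay on MDA-MB-231 cells (Homo sapiens) for inhibition, read by sulforhodamine B assay, with a stated time of 72 h; a higher number here means a weaker inhibitor of growth, a lower number a stronger inhibitor of growth:
Compound 1 `NC(=O)/C=C/c1ccncc1-c1ccc2ccccc2c1` gives > 10000 nM, a limit of the assay.
Compound 2 `CNC(=O)/C=C/c1ccncc1-c1ccc2c(cnn2C)c1` gives > 10000 nM, a limit of the assay.
Compound 3 `CNC(=O)CCc1ccncc1-c1ccc2ccccc2c1` gives 8980 nM.

Among the compounds with values here, compound 3 thus holds the only value that is a number; compounds 1 and 2 both sit at the limit of > 10000 nM in this assay, at which 2 of the 3 values shown sit, so the series is essentially flat at weak growth inhibition.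

Compound 4 `CNC(=O)/C=C/c1ccncc1-c1ccc2ccccc2c1` differs from compound 3 by 2-(methylcarbamoyl)ethenyl in place of 2-(methylcarbamoyl)ethyl on an aromatic carbon. Within the data shown here, the one measured step that bears on this change is an at least 1.1-fold lower number from compound 1 to compound 3 (0.04 log units; that floor lies within the scatter), which joins a swap of the double bond for a saturated chain with a methyl on the amide and still ends within the scatter. The step from compound 3 to compound 4 puts the double bond back while keeping the methyl on the amide, so no movement beyond the scatter in this assay is expected, with the limit of the assay close at hand. Compound 4 is expected at 11000 nM, in the range 5000 nM to 25000 nM, an expected step of a 1.2-fold higher number from compound 3 to compound 4 (0.09 log units; within the scatter).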

Compound 4, concentration for 50% growth inhibition: 8680 nM
Compound 4: middle estimate off by 1.3-fold (0.10 log units), on the high side, and the stated range covers the measured number.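

In this assay, within the data shown here, the first pair of numbers shows that the double bond of 2-(methylcarbamoyl)ethenyl and the saturated 2-(methylcarbamoyl)ethyl cannot be told apart at this position, opposite the ring nitrogen (a 1.0-fold lower number from compound 3 to compound 4 (0.01 log units; within the scatter)). The methyl on the amide-type nitrogen can now be read on its own, which the earlier step with its two joined changes did not allow, but this step starts from a limit of the assay and gives only a floor within the scatter (an at least 1.1-fold lower number from compound 1 to compound 4 (0.06 log units; that floor lies within the scatter)). Neither change lifts the series clear of the weak end of the assay, and the limit remains close: the limit of > 10000 nM in this assay, at which 2 of the 4 values shown sit.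

As far as these compounds go, it remains open whether any group at this position moves growth inhibition beyond the scatter. An amine, a carboxylic acid or a longer chain in place of the amide side chain would test this.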